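The compounds below may be only part of what the source reports. "The series", "measured", "known", "first", "only" and "open" are said of these compounds alone.

Compound 1 `CCN1C(=O)N(CC)C2C1NC(=S)N2/N=C/C=C/c1ccccc1[N+](=O)[O-]` and compound 2 `CCN1C(=O)N(CC)C2C1NC(=S)N2/N=C/C=C/c1ccccc1OC` share one core and differ in a single place: methoxy in place of nitro on an aromatic carbon. In a functional assay on RD cells (Homo sapiens) for inhibition, read by MTT assay, with a stated time of 72 h (on this read-out higher numbers stand for weaker inhibition and lower numbers for stronger inhibition), compound 1 gives 15300 nM, while compound 2 gives 250 nM, so the change made a 61-fold lower number from compound 1 to compound 2 (1.79 log units; beyond the scatter). Compound 3 `CCN1C(=O)N(CC)C2C1N=C(SC)N2/N=C/C=C/c1ccccc1[N+](=O)[O-]` carries the nitro group on a different core; the difference between the two cores is not broken down here. In this assay compound 3 gives 41900 nM, the highest of the three numbers and beyond the scatter from both others. Compound 4 `CCN1C(=O)N(CC)C2C1N=C(SC)N2/N=C/C=C/c1ccccc1OC` is not yet measured; it differs from compound 3 by methoxy in place of nitro on an aromatic carbon, the same change seen between compound 1 and compound 2. The step is expected to be a 60-fold lower number from compound 3 to compound 4 (1.78 log units; beyond the scatter), resting on a 61-fold lower number from compound 1 to compound 2 (1.79 log units; beyond the scatter), with some caution since the core is a different one. In this assay compound 4 is therefore estimated at 700 nM, within an expected range from 200 nM to 3000 nM.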

Compound 4, half-maximal inhibitory concentration: 7970 nM
Estimate against measurement, compound 4: 11-fold (1.06 log units) below; the whole stated range lies below it.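

In this assay, methoxy in place of nitro again gives a lower number, a 5.3-fold lower number from compound 3 to compound 4 (0.72 log units; beyond the scatter), so the direction of the change is the same on both cores shown. The size of the step does not carry over from one core to the other: the same change on two cores in this assay, a 61-fold lower number (1.79 log units; beyond the scatter) from compound 1 to compound 2 and a 5.3-fold lower number (0.72 log units; beyond the scatter) from compound 3 to compound 4, 12-fold (1.07 log units) apart, beyond the scatter of two such steps. Two pairs cannot show how large the step would be on any further core, nor which feature of the cores goes with the gap between the steps.

The compounds shown leave open how an amine or a carboxylic acid on the same aromatic carbon would read on either core. They also leave open whether a longer chain such as ethoxy would follow methoxy.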